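Swapping cyclohexyl for 4-bromo-2-methylphenyl on the amide

The source may hold more compounds than are shown below. What is called first, only, known or untested is meant among the compounds shown, and "the series" means these compounds.

In a functional assay on HEK293 cells for agonist activity at D(4) dopamine receptor (Homo sapiens), read by FLIPR (on this read-out lower numbers stand for smaller maximal responses and higher numbers for larger maximal responses), compound 1 `CCc1cccc(NC(=O)CN2CCC(c3cccc[n+]3[O-])CC2)c1` gives 62%, and compound 2 `O=C(CN1CCC(c2cccc[n+]2[O-])CC1)NC1CCCCC1` gives 58%. Compound 2 holds the lower of the two numbers, yet the step of a number 4 percentage points lower from compound 1 to compound 2 (within the scatter) lies within the scatter. Compound 3 `Cc1cc(Br)ccc1NC(=O)CN1CCC(c2cccc[n+]2[O-])CC1` differs from compound 2 by 4-bromo-2-methylphenyl in place of cyclohexyl on an amide-type nitrogen. Among the measured compounds shown here, the only measured step that bears on this change is a number 4 percentage points lower from compound 1 to compound 2 (within the scatter), in which cyclohexyl replaced an aryl group without any movement beyond the scatter; going back to an aryl group is therefore estimated to give a number 2 percentage points higher from compound 2 to compound 3 (within the scatter), a step not beyond the scatter. Compound 3 is expected to reach 60%, with a range from 45% to 75%.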

Compound 3, largest response reached (reported as efficacy), in percent of the reference or control that the assay uses: 61%
Compound 3: the middle estimate sits 1 percentage points below what was measured, and the stated range covers the measured number.
By their numbers in this assay, from the lowest: compounds 2, 3 and 1 (each within the scatter of the next).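

In this assay, replacing cyclohexyl with 4-bromo-2-methylphenyl gives a number 3 percentage points higher from compound 2 to compound 3 (within the scatter) and replacing 3-ethylphenyl with it gives a number 1 percentage points lower from compound 1 to compound 3 (within the scatter) on the same amide-type nitrogen. A third group at this position, now carrying bromine, thus leaves all three numbers within the scatter of one another, and neither the aromatic ring nor the added substituents separate them. No measurement offered here accounts for this result. As far as these compounds go, whether a group of another kind, such as a carboxylic acid or an amine, or a longer chain on this nitrogen would move the response beyond the scatter remains open.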